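The compounds below may be only part of what the source reports. "The series", "measured", "known", "first", "only" and "open" are said of these compounds alone.

Measured in a functional assay on MCF7 cells (Homo sapiens) for antiproliferative activity, with a stated time of 5 days; on this read-out higher numbers stand for weaker inhibition and lower numbers for stronger inhibition:

- compound 1 `COc1ccc(-c2[nH]c3ccc(OC)cc3c2C=O)cc1`: 180 nM
- compound 2 `CCCCc1ccc2[nH]c(-c3ccc(OC)cc3)c(C=O)c2c1`: 22 nM
- compound 3 `COc1ccc(-c2[nH]c3ccc(C(C)(C)C)cc3c2C=O)cc1`: 580 nM

Of these three, compound 3 has the highest number, 580 nM, and so the weakest inhibition. The next compound, compound 4 `CCCCCc1ccc2[nH]c(-c3ccc(OC)cc3)c(C=O)c2c1`, has pentyl in place of tert-butyl on an aromatic carbon.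

The most informative measured step is a 26-fold higher number from compound 2 to compound 3 (1.42 log units; beyond the scatter), a large change between butyl and tert-butyl. The other two steps are modest and point in opposite directions: an 8.2-fold lower number from compound 1 to compound 2 (0.91 log units; beyond the scatter) and a 3.2-fold higher number from compound 1 to compound 3 (0.51 log units; beyond the scatter). Within the data shown here, no pentyl compound has been measured yet, so how far a longer chain carries the trend is unknown. Among the measured groups, pentyl is closest to the butyl of compound 2 at 22 nM, so compound 4 is expected to land near that value. The expected change is a 19-fold lower number from compound 3 to compound 4 (1.29 log units; beyond the scatter), a large drop.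

The estimate for compound 4 is 30 nM, within an expected range of 10 nM to 100 nM.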

Compound 4, half-maximal inhibitory concentration: 20 nM
Compound 4: middle estimate off by 1.5-fold (0.18 log units), on the high side; measured number inside the range.
By their numbers in this assay, from the lowest: compounds 4 and 2 (each within the scatter of the next); then compound 1; then compound 3.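

In this assay, lengthening the chain by one carbon gives a 1.1-fold lower number from compound 2 to compound 4 (0.04 log units; within the scatter) and stays within the scatter, so butyl and pentyl cannot be told apart at this aromatic carbon. Moving from the branched tert-butyl to the unbranched pentyl gives a 29-fold lower number from compound 3 to compound 4 (1.46 log units; beyond the scatter) and matches the large gap already seen with butyl, which shows that this gap is not confined to a single chain. Pentyl in place of methoxy gives a 9.0-fold lower number from compound 1 to compound 4 (0.95 log units; beyond the scatter) in the same direction as butyl, whereas the tert-butyl of compound 3 goes against this pattern, and no supporting measurement here explains the difference.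

A longer chain such as hexyl or octyl could show whether the values hold or begin to rise. Isopropyl or isopentyl, or a chain ending in an amine or a carboxylic acid, would test how much other changes to the chain matter here.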